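The source may hold more compounds than are shown below. What is called first, only, known or untested is meant among the compounds shown, and "the series" means these compounds.

Measured in an ADME assay on MT4 cells (Homo sapiens) for cytotoxicity, read by MTT assay, with a stated time of 4 days; on this read-out higher numbers stand for lower toxicity in this test and lower numbers for higher toxicity in this test:

- Compound 1 `CC(=O)Nc1ccc2oc(-c3ccccc3)cc(=O)c2c1`: 184000 nM
- Compound 2 `CC(=O)Nc1ccc2oc(-c3ccccc3)c(O)c(=O)c2c1`: 64700 nM
- Compound 3 `COc1c(-c2ccccc2)oc2ccc(NC(C)=O)cc2c1=O`: 200000 nM

Compound 3 stands level with compound 1, as a 1.1-fold higher number from compound 1 to compound 3 (0.04 log units; within the scatter) shows, and clear of compound 2, with a 3.1-fold higher number from compound 2 to compound 3 (0.49 log units; beyond the scatter). It therefore belongs to the less toxic pair of this small set.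

The next compound, compound 4 `COc1ccc(-c2oc3ccc(NC(C)=O)cc3c(=O)c2OC)cc1`, keeps everything in compound 3 but changes phenyl to 4-methoxyphenyl, which puts methoxy in place of hydrogen on an aromatic carbon. Among the measured compounds shown here, no measured step touches this phenyl group, so the evidence is indirect. For the measured compounds named here, the closest precedent is the same exchange at a different place on the molecule, and there a 1.1-fold higher number from compound 1 to compound 3 (0.04 log units; within the scatter). The only clear movement among these compounds involves a free hydroxy group: a 2.8-fold lower number from compound 1 to compound 2 (0.45 log units; beyond the scatter), then a 3.1-fold higher number from compound 2 to compound 3 (0.49 log units; beyond the scatter) once that hydroxy is capped with methyl. Compound 4 gains no such hydroxy group.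

A small change in this assay is therefore expected, perhaps slightly downward and probably within the scatter. The expected step is a 1.3-fold lower number from compound 3 to compound 4 (0.12 log units; within the scatter). For compound 4 the estimated value is 150000 nM, with an expected range of 60000 nM to 280000 nM.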

Compound 4, half-maximal cytotoxic concentration: 369000 nM
The estimate for compound 4 lay 2.5-fold (0.39 log units) below the measured number, outside the stated range (above it).
By their numbers in this assay, from the lowest: compound 2; then compounds 1, 3 and 4 (each within the scatter of the next).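

In this assay, replacing phenyl with 4-methoxyphenyl in compound 3 gives a 1.8-fold higher number from compound 3 to compound 4 (0.27 log units; within the scatter), so methoxy in place of hydrogen at this place, para to a large group, does not shift the number beyond the scatter. The same exchange at the other aromatic carbon, a 1.1-fold higher number from compound 1 to compound 3 (0.04 log units; within the scatter), also stays within the scatter, so neither methoxy placement shows the clear movement seen with the free hydroxy group, a 2.8-fold lower number from compound 1 to compound 2 (0.45 log units; beyond the scatter). Nothing measured here explains the size of the step at the new position.

As far as these compounds go, it remains open whether a hydroxy group at this place on the phenyl ring would lower the number as it does on the shared core, and what an amine or a carboxylic acid would do there. From the compounds shown here alone, it is also open whether 4-methoxyphenyl would behave the same way on the core of compound 1 or compound 2, where the neighbouring group on the core differs from that in compound 3.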